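Pentyl for 2-methoxyphenyl on the piperidine side chain

A few compounds are considered here, and "the series" means these few. Any claim that something is new, unique, unknown or untested is made for them only; others in the source may bear on it.

Three measured compounds share a core in which a ring amine carries a chain ending in an aryl group. In a functional assay on cells (T-cell line, Homo sapiens) for inhibition (a lower number here means a stronger inhibitor, a higher number a weaker inhibitor), compound 1 `COc1ccc(CCCN2CCC(CNC(c3ccccc3)c3ccccc3)CC2)cc1` gives 2800 nM, compound 2 `COc1ccc(CCCN2CCC(COC(c3ccc(Br)cc3)c3ccc(Br)cc3)CC2)cc1` gives 3200 nM, and compound 3 `COc1ccccc1CCCN1CCC(COC(c2ccccc2)c2ccccc2)CC1` gives 2400 nM. Compound 3 carries the smallest of the three numbers, yet its gaps to compound 1 and to compound 2 both lie within the scatter, so the three stand together. Compound 4 `CCCCCCCCN1CCC(COC(c2ccccc2)c2ccccc2)CC1` differs from compound 3 by pentyl in place of 2-methoxyphenyl on a saturated chain carbon, three bonds along the chain from an amine nitrogen in a ring. For the measured compounds named here, no measured pair covers a change of this kind. The aryl variations between compound 1, compound 2 and compound 3 shift nothing beyond the scatter, so the step from compound 3 to compound 4 is expected small, if anything toward a weaker inhibitor, at a 1.7-fold higher number from compound 3 to compound 4 (0.22 log units; within the scatter). Compound 4 is therefore expected near 4000 nM, within 1500 nM to 12000 nM.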

Compound 4, half-maximal inhibitory concentration: 700 nM
Estimate against measurement, compound 4: 5.7-fold (0.76 log units) above; measured number below the stated range.
By their numbers in this assay, from the lowest: compound 4; then compounds 3, 1 and 2 (each within the scatter of the next).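

Pentyl in place of 2-methoxyphenyl on a saturated chain carbon, three bonds along the chain from an amine nitrogen in a ring, gives a 3.4-fold lower number from compound 3 to compound 4 (0.54 log units; beyond the scatter) in this assay. This position therefore responds to change, and an aromatic ring there is not required for inhibition in compound 4. No supporting data on the origin of this step are available.

Going by these compounds, it remains open whether a longer chain at this carbon would lower the number further. Cyclohexyl there would test whether an open chain is needed.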